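Methoxy in place of hydrogen on the ketone aryl ring

The compounds below may be only part of what the source reports. "The series", "measured", "known", "first", "only" and "open" are said of these compounds alone.

Measured so far:
compound 1 `COc1cc(-c2cc(/C=C/C(=O)c3ccc(N)cc3)[nH]n2)cc(OC)c1OC`: 1600 nM
compound 2 `COc1ccc(C(=O)/C=C/c2cc(-c3cc(OC)c(OC)c(OC)c3)n[nH]2)cc1OC`: 510 nM
compound 3 `COc1cc(-c2cc(/C=C/C(=O)c3ccccc3)[nH]n2)cc(OC)c1OC`: 2100 nM

In a functional assay on MCF7 cells (Homo sapiens) for inhibition, read by MTT assay, with a stated time of 48 h (on this read-out lower numbers stand for stronger inhibition and higher numbers for weaker inhibition), compound 3 gives the highest number of the three. The gap to compound 1 is within the scatter, a 1.3-fold higher number from compound 1 to compound 3 (0.12 log units; within the scatter); the gap to compound 2 is beyond it, a 4.1-fold higher number from compound 2 to compound 3 (0.61 log units; beyond the scatter). Compound 4 `COc1ccc(C(=O)/C=C/c2cc(-c3cc(OC)c(OC)c(OC)c3)n[nH]2)cc1` differs from compound 3 by methoxy in place of hydrogen on an aromatic carbon. The step that bears on this is a 4.1-fold higher number from compound 2 to compound 3 (0.61 log units; beyond the scatter), where two methoxy groups were removed from the same ring; the step of a 1.3-fold higher number from compound 1 to compound 3 (0.12 log units; within the scatter) shows that not every group at this place moves the number. For a single methoxy, a lowering of smaller size is expected, a 2.1-fold lower number from compound 3 to compound 4 (0.32 log units; beyond the scatter). Compound 4 is therefore estimated at 1000 nM, with a range from 400 nM to 2500 nM.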

Compound 4, half-maximal inhibitory concentration: 810 nM
The estimate for compound 4 lay 1.2-fold (0.09 log units) above the measured number, within the range that was stated.
By their numbers in this assay, from the lowest: compounds 2, 4, 1 and 3 (each within the scatter of the next, the first and the last beyond it).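

In this assay, a single methoxy para to a large group on the ketone ring, the change from phenyl to 4-methoxyphenyl, is enough to move the number beyond the scatter (a 2.6-fold lower number from compound 3 to compound 4 (0.41 log units; beyond the scatter)). The further methoxy of compound 2 adds nothing that separates from the scatter (a 1.6-fold higher number from compound 2 to compound 4 (0.20 log units; within the scatter)). Methoxy and amino at this place also stay within the scatter of each other (a 2.0-fold lower number from compound 1 to compound 4 (0.30 log units; within the scatter)).

From the compounds shown here alone, whether fluorine, hydroxyl or ethoxy at this place would match methoxy stays open. No measurement shown gives a reason for these steps.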